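Swapping the methylamino for 4-methylpiperidin-1-yl

A few compounds are considered here, and "the series" means these few. Any claim that something is new, unique, unknown or untested is made for them only; others in the source may bear on it.

Compound 1: `COc1ccc(Nc2nccc(-c3ccccn3)n2)cc1` gives 8300 nM in a functional assay for inhibition, with Homo sapiens as the target; a higher number here means a weaker inhibitor, a lower number a stronger inhibitor.
Compound 2: `CNc1ccc(Nc2nccc(-c3ccccn3)n2)cc1` gives 1400 nM in this assay.

Compound 2 stands at the lowest of the two numbers seen so far in this assay; its nearest neighbour is compound 1, separated by a 5.9-fold lower number from compound 1 to compound 2 (0.77 log units; beyond the scatter). Compound 3 is `CC1CCN(c2ccc(Nc3nccc(-c4ccccn4)n3)cc2)CC1`, obtained from compound 2 by the change (4-methylpiperidin-1-yl in place of methylamino on an aromatic carbon). Among the measured compounds shown here, the only measured step, a 5.9-fold lower number from compound 1 to compound 2 (0.77 log units; beyond the scatter), concerns the same position and was modest, so no more than a modest shift in this assay is expected here, its direction uncertain. For compound 3 an estimate of 900 nM is given, within 200 nM to 4000 nM, an expected 1.6-fold lower number from compound 2 to compound 3 (0.19 log units; within the scatter).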

Compound 3, half-maximal inhibitory concentration: 1900 nM
For compound 3 the middle estimate is 2.1-fold (0.32 log units) below the measured one; measured number inside the range.
By their numbers in this assay, from the lowest: compounds 2 and 3 (each within the scatter of the next); then compound 1.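

In this assay, the entering 4-methylpiperidin-1-yl brings a six-membered non-aromatic ring and 7 heavy atoms to this aromatic carbon, yet the step is a 1.4-fold higher number from compound 2 to compound 3 (0.13 log units; within the scatter), so compound 2 and compound 3 cannot be told apart. The other step, a 4.4-fold lower number from compound 1 to compound 3 (0.64 log units; beyond the scatter), shows that the move away from methoxy does not depend on a hydrogen-bond donor in the entering group. Nothing here gives a measured reason for these numbers. Still open, on these data alone, is how a morpholine or a carboxylic acid on this carbon would read, and whether a longer chain ending in an amine would lower the number further.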